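Methyl for Hydrogen on an Aromatic Oxygen

The source may report more compounds than this note shows. Statements on the series, on what has been measured and on what is new or still open speak of the compounds shown alone.

Three close relatives of one shared core have been tested in a functional assay on DLD-1 cells (Homo sapiens) for cytotoxicity, with a stated time of 48 h; a higher number here means a weaker inhibitor, a lower number a stronger inhibitor. Compound 1 `CC(C)COc1ccc2oc(/C=C/[S+](C)[O-])cc(=O)c2c1`, which carries an isobutyl group on an oxygen on an aromatic ring, gives 5000 nM in this assay. Compound 2 `C[S+]([O-])/C=C/c1cc(=O)c2cc(O)ccc2o1`, with a bare hydroxy group in that place, reaches only the limit of this assay, > 10000 nM, so no number is known for it. Compound 3 `COc1cccc2c(=O)cc(/C=C/[S+](C)[O-])oc12`, which carries a methoxy group at a different place on the core, gives 9000 nM in this assay. Among the compounds with values here, the one measured step is an at least 2.0-fold higher number from compound 1 to compound 2 (0.30 log units; that floor lies within the scatter), and its size is fixed only by the limit of > 10000 nM in this assay, at which 1 of the 3 values shown sits.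

Compound 4 `COc1ccc2oc(/C=C/[S+](C)[O-])cc(=O)c2c1` differs from compound 2 by methyl in place of hydrogen on an oxygen on an aromatic ring. This puts a small alkyl cap back on the oxygen that carries isobutyl in compound 1. Since taking the cap off gave a higher number in this assay, restoring a shorter cap is expected to bring the number back down, though not necessarily as far as the isobutyl compound. For compound 4 the expected value is 8000 nM, between 3000 nM and 20000 nM. The expected step is an at least 1.2-fold lower number from compound 2 to compound 4 (0.09 log units; that floor lies within the scatter).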

Compound 4, half-maximal inhibitory concentration: 5700 nM
Estimate against measurement, compound 4: 1.4-fold (0.15 log units) above; low and high end bracket the measured number.
By their numbers in this assay, from the lowest: compounds 1, 4 and 3 (each within the scatter of the next). At a limit, above all of these: compound 2.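

The new result shows that on this oxygen a methyl cap cannot be told apart from the much larger isobutyl group in this assay, with a 1.1-fold higher number from compound 1 to compound 4 (0.06 log units; within the scatter). Within this pair, then, the extra carbons of the isobutyl group bring no visible difference. Going from the bare hydroxy group to methoxy gives an at least 1.7-fold lower number from compound 2 to compound 4 (0.24 log units; that floor lies within the scatter), and compound 2 supplies only a limit, not a number, so the true size of this step is unknown: the limit of > 10000 nM in this assay, at which 1 of the 4 values shown sits.

Going by these compounds, it remains open whether a chain longer than isobutyl, or a ring such as benzyl, on this oxygen would move the number beyond the scatter. Also open, on these data alone, is what a chain ending in an amine or a carboxylic acid would do in this place.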